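A urea-to-benzamide step in a pyrazole series

The compounds below may be only part of what the source reports. "The series", "measured", "known", "first", "only" and "open" are said of these compounds alone.

Compound 2 `COc1cc(-c2nn(-c3cccc(NC(=O)Nc4ccc(Cl)c(C(F)(F)F)c4)c3)cc2-c2ccncc2)ccc1Cl` and compound 1 `COc1cc(-c2nn(-c3cccc(NC(=O)Nc4cccc(C(F)(F)F)c4)c3)cc2-c2ccncc2)ccc1Cl` share one core and differ only in a chloro in place of hydrogen on an aromatic carbon. In a functional assay on HOP-62 cells (Homo sapiens) for inhibition, read by sulforhodamine B assay, with a stated time of 48 h (a lower number here means a stronger inhibitor of growth, a higher number a weaker inhibitor of growth), compound 2 gives 6490 nM, which is the highest of the two numbers recorded, while compound 1 gives 4070 nM; the change a 1.6-fold higher number from compound 1 to compound 2 (0.20 log units; within the scatter) lies within the scatter, so the two compounds cannot be ranked against each other on this assay.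

Compound 3 `COc1cc(-c2nn(-c3cccc(NC(=O)c4ccccc4)c3)cc2-c2ccncc2)ccc1Cl` has not been measured. It differs from compound 2 by phenyl in place of (4-chloro-3-(trifluoromethyl)phenyl)amino on a carbonyl carbon, so the whole arylamino part of the urea is gone and a plain benzamide remains. Going by the values given here, the only measured step, a 1.6-fold higher number from compound 1 to compound 2 (0.20 log units; within the scatter), concerns a substituent on the very ring that now leaves, and it was within the scatter; it therefore offers no direct guidance on removing that ring along with its attached nitrogen. The change in compound 3 is larger than anything measured here, so a step beyond the scatter is expected, towards a higher number. Compound 3 is estimated at 13000 nM, with a range of 4000 nM to 40000 nM, which would be an expected step of a 2.0-fold higher number from compound 2 to compound 3 (0.30 log units; within the scatter).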

Compound 3, concentration for total growth inhibition: > 100000 nM
Compound 3: no number, only a limit (the forecaster's own chance of this, stated with the estimate: 10%); middle value at least 7.6-fold (0.88 log units) away from the limit.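

In this assay, putting phenyl in place of the arylamino part on the carbonyl carbon gives an at least 15-fold higher number from compound 2 to compound 3 (1.18 log units; beyond the scatter), and the same kind of change without the chloro gives an at least 24-fold higher number from compound 1 to compound 3 (1.39 log units; beyond the scatter). The earlier pair showed only a step within the scatter for a chloro on the ring that leaves, whereas both of these steps lie beyond the scatter, so this position responds strongly to the loss of the whole arylamino part even though it barely registered that single substitution. The value of compound 3, > 100000 nM, is a limit of the assay and not a number: the limit of > 100000 nM in this assay, at which 1 of the 3 values shown sits.

The compounds shown lose the urea nitrogen and the substituents on the ring in a single change, so they leave open which of these losses accounts for the steps. A phenylamino group on the carbonyl carbon, which keeps the nitrogen without the chloro or trifluoromethyl, or a benzylamino group there, which adds a carbon to the link, would be needed to tell these apart.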